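The source may hold more compounds than are shown below. What is called first, only, known or untested is meant among the compounds shown, and "the series" means these compounds.

Compound 1 `COC(=O)c1c(F)cccc1-c1ccc(CCc2ncc(CC(C)(C)C)n2CCNS(C)(=O)=O)cc1` gives 7 nM in an assay on cells for agonist activity at Bombesin receptor subtype-3 (Mus musculus), read by HTRF and inositol phosphate accumulation, with a stated time of 1 h; a lower number here means that less compound is needed, a higher number that more compound is needed for the effect. Compound 2 `CC(C)(C)Cc1cnc(CCc2ccc(-c3cccc(F)c3C(=O)O)cc2)n1CCOc1cccc(O)c1` gives 0.8 nM in this assay.

Compound 2 stands lowest of the two numbers; compound 1 sits higher by a gap beyond the scatter. Compound 3 `CC(C)(C)Cc1cnc(CCc2ccc(-c3cccc(F)c3C(=O)O)cc2)n1CCNS(C)(=O)=O` differs from compound 2 by methanesulfonamido in place of 3-hydroxyphenoxy on a saturated chain carbon, two bonds along the chain from an aromatic nitrogen. Within the data shown here, no measured pair isolates this change: compound 1 carries the same methanesulfonamido chain as compound 3 but differs from compound 2 elsewhere as well, so its value only loosely frames the expectation. The step of a 3.8-fold higher number from compound 2 to compound 3 (0.57 log units; beyond the scatter) is expected to raise the number, probably beyond the scatter. Compound 3 is estimated at 3 nM, within 0.8 nM to 12 nM.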

Compound 3, half-maximal effective concentration: 4 nM
Estimate against measurement, compound 3: 1.3-fold (0.12 log units) below, and the stated range covers the measured number.
By their numbers in this assay, from the lowest: compound 2; then compounds 3 and 1 (each within the scatter of the next).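

Among these compounds, on the saturated chain carbon, two bonds along the chain from an aromatic nitrogen, methanesulfonamido in place of 3-hydroxyphenoxy gives a 5.0-fold higher number from compound 2 to compound 3 (0.70 log units; beyond the scatter) in this assay as the first isolated reading of this swap, so a group with no ring is tolerated here at a modest cost. Hydrogen in place of methyl on an oxygen next to a carbonyl group gives a 1.8-fold lower number from compound 1 to compound 3 (0.24 log units; within the scatter) and so separates the methyl ester from the carboxylic acid by no more than the scatter. No supporting data bear on the cause of either step.

From the compounds shown here alone, whether plain phenoxy, an amine or a longer chain at this position would stay close to compound 2 remains open.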